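Lengthening a Chain in a Rat Inhibition Study

This account rests on a few compounds, and the source may have more. Where it says the series, first, only, none or still open, it means among the compounds named here.

Compound 1, `CCC/N=C(\S)n1ncnc1N`: 93%
Compound 2, `Nc1ncnn1/C(S)=N/c1ccccc1`: -7%

In a functional assay on the whole organism for inhibition, with Rattus norvegicus as the target, at a dose of 30 mg/kg (a lower number here means less inhibition, a higher number more inhibition at the dose given (going by the name of the read-out)), compound 1 gives 93%, the highest of the two numbers available. Within the data shown here, its only neighbour, compound 2, gives -7%, a gap that lies far beyond the usual scatter of such measurements. Among the measured compounds shown here, the two structures share the same core; compound 1 carries a propyl chain where compound 2 carries a ring, and no single-point step between them has been measured, so only the two values themselves can be compared.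

Compound 3, `Nc1ncnn1/C(S)=N/CCCCCO`, has not yet been measured in this assay. It differs from compound 1 by 2-hydroxyethyl in place of hydrogen on a saturated chain carbon, three bonds along the chain from a double-bonded nitrogen. The chain is kept, so the drop seen in compound 2, which gives -7%, need not be repeated; still, the chain grows, and a moderate loss of inhibition beyond the scatter is expected, though a result close to compound 1 cannot be ruled out. The step from compound 1 to compound 3 is estimated as a number 33 percentage points lower from compound 1 to compound 3 (beyond the scatter). Compound 3 is thus expected to give about 60%, within a range from 15% to 95%.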

Compound 3, a percentage reported as inhibition, in the whole organism at one dose (the size of the read-out at that dose, not a potency): -17%
Compound 3: the middle estimate sits 77 percentage points above what was measured; the whole stated range lies above it.
By their numbers in this assay, from the lowest: compounds 3 and 2 (each within the scatter of the next); then compound 1.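

This position on the chain of compound 1 is far from indifferent: in this assay, with 2-hydroxyethyl in place of hydrogen on a saturated chain carbon, three bonds along the chain from a double-bonded nitrogen, the result is a number 110 percentage points lower from compound 1 to compound 3 (beyond the scatter). Among these compounds, until now, the only low value came from a compound carrying a ring instead of a chain, but an open chain clearly does not guarantee inhibition: compound 3 gives -17% and compound 2 gives -7%, two values within the usual scatter of each other. Nothing available explains why the inhibition is lost at this position.

The change makes the chain longer and also adds a hydroxyl group, and these two compounds cannot show which of the two matters, or whether both do. A plain pentyl chain would separate the effect of length from that of the hydroxyl group, while a butyl chain would show whether inhibition fades gradually as the chain grows or disappears abruptly beyond propyl.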